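Spiro hydantoin quinolines in the maximal electroshock model

A few compounds are considered here, and "the series" means these few. Any claim that something is new, unique, unknown or untested is made for them only; others in the source may bear on it.

Measured so far:
- compound 1, `O=C1NC2(CC2c2ccc3cccc(OCc4ccccc4)c3n2)C(=O)N1c1ccc(C(F)(F)F)cc1`: 300 mg/kg
- compound 2, `CC(C)N1C(=O)NC2(CC2c2ccc3cccc(OCc4ccccc4)c3n2)C1=O`: 300 mg/kg

In a functional assay on the whole organism (strain Kunming) with Mus musculus as the target, in the maximal electroshock model, with a stated time of 0.5 h (a higher number here means that more compound is needed for the effect, a lower number that less compound is needed), compound 1 gives 300 mg/kg. Compound 2 carries isopropyl on the amide-type nitrogen in the ring in place of the 4-(trifluoromethyl)phenyl of compound 1, and in this assay compound 2 gives 300 mg/kg. Among the compounds with values here, the one measured step, no change at the digits printed from compound 1 to compound 2 (within the scatter), shows that exchanging an aryl group for a small alkyl group at that nitrogen left the minimum effective dose where it was. Compound 2 thus stands level with compound 1 at the digits shown; there is no ordering between them.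

Compound 3, `O=C1NC2(CC2c2ccc3cccc(OCc4ccccc4)c3n2)C(=O)N1c1ccc(F)cc1`, has not been measured. It differs from compound 2 as 4-fluorophenyl in place of isopropyl on an amide-type nitrogen in a ring, which returns an aryl group to the same nitrogen, now bearing fluorine instead of trifluoromethyl. Within the data shown here, the only step that bears on it is the one from compound 1 to compound 2, which was flat, so no change beyond the scatter is expected; the step of no change at the digits printed from compound 2 to compound 3 (within the scatter) is estimated as essentially none. Compound 3 is expected to give about 300 mg/kg in this assay, with a range from 100 mg/kg to 600 mg/kg.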

Compound 3, minimum effective dose: 300 mg/kg
Beside the measured number, compound 3's estimate shows no gap at the digits printed, and the stated range covers the measured number.
By their numbers in this assay, from the lowest: compounds 1, 2 and 3 (each within the scatter of the next).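

In this assay the aryl group on the amide-type nitrogen in a ring, 4-fluorophenyl in place of isopropyl, gives no change at the digits printed from compound 2 to compound 3 (within the scatter) and a change inside that aryl group, fluoro in place of trifluoromethyl on an aromatic carbon, gives no change at the digits printed from compound 1 to compound 3 (within the scatter) while the shared core stays the same. This position now holds an alkyl group and two substituted phenyl groups with no separation among the three compounds, and the substituent on the phenyl ring, which the earlier pair did not compare on its own, does not separate them either. No supporting measurement bears on why these exchanges leave the minimum effective dose in place.

Still open, on these data alone, is whether any group at this nitrogen shifts the dose beyond the scatter, for example a chain ending in an amine or a carboxylic acid, or a longer alkyl chain in place of isopropyl. Also open, as far as these compounds go, is whether a change elsewhere, such as replacing the benzyloxy group of the shared core with a hydroxyl group, would separate compounds that changes at this nitrogen leave level.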